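Chain-to-isoxazole swap in the cinnamoyl cytotoxicity series

This account rests on a few compounds, and the source may have more. Where it says the series, first, only, none or still open, it means among the compounds named here.

Working notes on a small set tested in a functional assay on MCF7 cells (Homo sapiens) for cytotoxicity, read by MTT assay, with a stated time of 72 h; on this read-out higher numbers stand for weaker inhibition and lower numbers for stronger inhibition. Compound 1 `COc1ccc(/C=C/C(=O)CC(C)=O)cc1OC` gives 10600 nM in this assay. Compound 2 `Cc1cc(/C=C/c2ccc(O)c(O)c2)[nH]n1` gives 23200 nM, and compound 3 `CC(=O)CC(=O)/C=C/c1ccc(O)cc1` gives 19700 nM. Compound 1 has the lowest number of the three: its gap to compound 2 lies beyond the scatter, whereas its gap to compound 3 lies within the scatter, so compound 1 and compound 3 are not distinguished on this read-out.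

The next entry is compound 4 `COc1ccc(/C=C/c2cc(C)no2)cc1OC`, not yet measured in this assay. Relative to compound 1 the change is 3-methyl-1,2-oxazol-5-yl in place of (2-oxopropyl)carbonyl on a double-bonded chain carbon bound to a double-bonded chain carbon. Within the data shown here, no measured pair in the set isolates this change, so its size is unknown. Among the measured compounds shown here, only one other compound here carries a five-membered aromatic ring on the chain, and that compound, compound 2, gives 23200 nM. On that basis compound 4 is expected to land near compound 1, with the step of a 1.4-fold higher number from compound 1 to compound 4 (0.15 log units; within the scatter) expected to stay within the scatter or edge toward a higher number. The estimate for compound 4 is 15000 nM, with a range from 5000 nM to 45000 nM.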

Compound 4, half-maximal inhibitory concentration: > 100000 nM
Compound 4: a limit, no number; the forecaster's own chance of this, stated with the estimate: 10%; at least 6.6-fold (0.82 log units) between middle value and limit.
By their numbers in this assay, from the lowest: compounds 1, 3 and 2 (each within the scatter of the next, the first and the last beyond it). At a limit, above all of these: compound 4.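

In this assay compound 4 reads as a limit and not a number: the limit of > 100000 nM in this assay, at which 1 of the 4 values shown sits. Exchanging the open chain for the five-membered aromatic ring gives an at least 9.4-fold higher number from compound 1 to compound 4 (0.97 log units; beyond the scatter), the first step measured at this position. The two groups have matching counts of heavy atoms, hydrogen-bond donors and hydrogen-bond acceptors, yet they are not interchangeable here, so those counts alone do not carry the level of compound 1.

The limit bounds the step from one side only, and this single pair cannot separate the loss of the open chain from the arrival of the ring. From the compounds shown here alone, whether an amide or a carboxylic acid on the same chain carbon would hold the level of compound 1 remains open.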